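Trimming a Methylcarbamoyl Group in a Lymphoma Cell Assay

The compounds below may be only part of what the source reports. "The series", "measured", "known", "first", "only" and "open" are said of these compounds alone.

For the measured compounds named here, compound 1 `CNC(=O)c1ccc(-c2cnc(NCc3c(F)ccc4c3CCO4)c3cn[nH]c(=O)c23)c(C)n1` is the only compound here for which a number exists. In a functional assay on KARPAS-422 cells (Homo sapiens) for inhibition, read by luminescence and CellTiter-Glo, with a stated time of 14 days (on this read-out higher numbers stand for weaker inhibition of growth and lower numbers for stronger inhibition of growth), compound 1 gives 13 nM, so it stands alone with nothing to be ranked against. Compound 2 `O=C1CC2(CC2)CN1c1cnc(NCc2c(F)ccc3c2CCO3)n2cnnc12` has only "not determined" (no result reported) in this assay and offers no comparison. Compound 3 `Cc1ncccc1-c1cnc(NCc2c(F)ccc3c2CCO3)c2cn[nH]c(=O)c12` differs from compound 1 in a single place: hydrogen in place of methylcarbamoyl on an aromatic carbon. Going by the values given here, no step between two measured compounds is available to calibrate such a change, so the expectation rests on the structures alone. The group that leaves counts one hydrogen-bond donor and one hydrogen-bond acceptor, which compound 3 no longer has, and the step is expected to run toward weaker inhibition of growth by about a 4.6-fold higher number from compound 1 to compound 3 (0.66 log units; beyond the scatter), beyond the usual scatter. Compound 3 is therefore expected to reach 60 nM, with a range from 15 nM to 250 nM.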

Compound 3, concentration for 50% growth inhibition: 37 nM
Compound 3: the middle estimate sits 1.6-fold (0.21 log units) above what was measured; the range from low to high includes it.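

In this assay, for the compounds shown here, the first measured step at this position is a 2.8-fold higher number from compound 1 to compound 3 (0.45 log units; beyond the scatter) and it lies beyond the scatter, so replacing methylcarbamoyl with hydrogen, on the aromatic carbon next to the ring nitrogen, has a modest cost in growth inhibition. Compound 3, with only hydrogen there, still gives 37 nM and so keeps much of the inhibition, which means methylcarbamoyl adds to the activity of this series without carrying all of it. No measurement here explains why the number moves, so the step can be described but not accounted for.

As far as these compounds go, it remains open whether another group at this position, such as an amine, a carboxylic acid or a longer chain, would match compound 1 or fall short of compound 3. A single step also cannot show whether the same change would cost as much on a different core.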